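A Methoxy Substituent on the Aryl Piperazine Series

A few compounds are considered here, and "the series" means these few. Any claim that something is new, unique, unknown or untested is made for them only; others in the source may bear on it.

Compound 3 `CCCc1nc(-c2ccccc2)c(CNCCN2CCN(c3ccc(C)cc3)CC2)o1` stands second of three on the numbers measured in an assay on HEK293 cells for inhibition of Voltage-dependent T-type calcium channel subunit alpha-1G (Homo sapiens), read by fluorescence, tested at 10 uM (a higher number here means more inhibition at the concentration tested (going by the name of the read-out), a lower number less inhibition), where compound 3 gives 48.1%. Compound 1 `CCCc1nc(-c2ccccc2)c(CNCCN2CCN(c3ccc(Cl)cc3)CC2)o1` gives 55.8%, and compound 2 `CCCc1nc(-c2ccccc2)c(CNCCN2CCN(c3cccc(C)c3)CC2)o1` gives 43.1%; both lie within the scatter of compound 3. The steps of a number 7.7 percentage points lower from compound 1 to compound 3 (within the scatter) and a number 5 percentage points higher from compound 2 to compound 3 (within the scatter) are small, while a number 12.7 percentage points lower from compound 1 to compound 2 (beyond the scatter). Compound 4 `CCCc1nc(-c2ccccc2)c(CNCCN2CCN(c3ccc(OC)cc3)CC2)o1` carries one change from compound 3: methoxy in place of methyl on an aromatic carbon. Among the measured compounds shown here, no measured step exchanges methyl for methoxy on this ring, so the only guides are the small steps around compound 3. Compound 4 is therefore expected to show a step of a number 3.1 percentage points lower from compound 3 to compound 4 (within the scatter), within the scatter. Compound 4 is estimated at 45%, with a range from 28% to 62%.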

Compound 4, a percentage reported as inhibition, at one concentration (the size of the read-out at that concentration, not a potency): 51.5%
For compound 4 the middle estimate is 6.5 percentage points below the measured one, within the range that was stated.
By their numbers in this assay, from the lowest: compounds 2, 3, 4 and 1 (each within the scatter of the next, the first and the last beyond it).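

In this assay, the change from 4-methylphenyl to 4-methoxyphenyl adds one oxygen and one hydrogen-bond acceptor, yet gives only a number 3.4 percentage points higher from compound 3 to compound 4 (within the scatter). Compound 4 also stays close to its other neighbours, with a number 8.4 percentage points higher from compound 2 to compound 4 (within the scatter) and a number 4.3 percentage points lower from compound 1 to compound 4 (within the scatter), so chloro, methyl and methoxy at this position cannot be told apart by this read-out. No evidence on the cause of these steps is available. Still open, on these data alone, is whether an amine or a carboxylic acid at this position would move the number beyond the scatter.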